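A few compounds are considered here, and "the series" means these few. Any claim that something is new, unique, unknown or untested is made for them only; others in the source may bear on it.

Working notes on the series. Among the measured compounds shown here, compound 1 `CCCOC1=C(CCC)C(=O)/C(=C(O)/C=C/c2ccccc2)C(=O)C1(CCC)CCC` gives 1.9 uM in a functional assay on A549 cells (Homo sapiens) for antiproliferative activity, read by sulforhodamine B assay, with a stated time of 3 days (a higher number here means that more compound is needed for the effect, a lower number that less compound is needed), the lowest of the two numbers so far. For the measured compounds named here, the nearest is compound 2 `CCCC1(CC=C(C)C)C(=O)C(C(=O)/C=C/c2ccccc2)=C(O)C(CCC)(CCC)C1=O`, which gives 7.1 uM in this assay, a gap beyond the scatter; the two compounds differ in more than one place, so the numbers alone say only that compound 1 carries the lower one.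

Compound 3 `CCCC1=C(OCC(C)C)C(CCC)(CCC)C(=O)/C(=C(O)\C=C\c2ccccc2)C1=O` is next in this assay. It departs from compound 1 by methyl in place of hydrogen on a saturated chain carbon bound to two saturated chain carbons. Going by the values given here, no measured pair in the set isolates this kind of change, so there is no step of the same type to lean on. With one carbon added on a saturated chain and no change in donors, acceptors or charge, the expectation is a step within the scatter, in no firm direction. The value for compound 3 is estimated at 2.2 uM, range 1 uM to 5 uM, a step of a 1.2-fold higher number from compound 1 to compound 3 (0.06 log units; within the scatter) that is expected to stay within the scatter.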

Compound 3, concentration for half-maximal effect: 1.7 uM
The estimate for compound 3 lay 1.3-fold (0.11 log units) above the measured number, and the stated range covers the measured number.
By their numbers in this assay, from the lowest: compounds 3 and 1 (each within the scatter of the next); then compound 2.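

Changing propoxy to isobutoxy gives a 1.1-fold lower number from compound 1 to compound 3 (0.05 log units; within the scatter) in this assay. Among the compounds shown here, this is the first comparison with a single change, which the earlier pair of compounds, differing in more than one place, could not provide. At this position, methyl in place of hydrogen on a saturated chain carbon bound to two saturated chain carbons leaves the number within the scatter, and nothing available gives a reason for this result.

As far as these compounds go, whether the position also accepts a much longer chain, such as decyloxy, or a chain carrying an amine or a carboxylic acid remains open. A single added methyl also leaves open whether the step would stay within the scatter on the other chains of the core or on other cell lines.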